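Swapping a nitrophenyl ketone for a furyl ketone

This account rests on a few compounds, and the source may have more. Where it says the series, first, only, none or still open, it means among the compounds named here.

Compound 1, `COc1cc(-c2nnc3n2NC(c2ccco2)C(C(=O)c2ccccc2F)S3)cc(OC)c1OC`, in a functional assay on HepG2 cells (Homo sapiens) for cytotoxicity, read by MTT assay, with a stated time of 48 h; on this read-out lower numbers stand for stronger inhibition and higher numbers for weaker inhibition: > 100000 nM
Compound 2, `COc1ccc(C(=O)C2Sc3nnc(-c4cc(OC)c(OC)c(OC)c4)n3NC2c2ccco2)cc1`, in this assay: > 100000 nM
Compound 3, `COc1cc(-c2nnc3n2NC(c2ccco2)C(C(=O)c2ccc([N+](=O)[O-])cc2)S3)cc(OC)c1OC`, in this assay: 87800 nM

Three measured compounds share one core and differ only in the group attached to the carbonyl carbon. The value of compound 1 is a limit of this assay, not a number. The value of compound 2 is likewise a limit (the limit of > 100000 nM in this assay, at which 2 of the 3 values shown sit). For the measured compounds named here, compound 3 is therefore the only compound with a number, and it stands near the top of the measured range, which means weak cytotoxicity. The steps of an at least 1.1-fold lower number from compound 1 to compound 3 (0.05 log units; that floor lies within the scatter) and an at least 1.1-fold lower number from compound 2 to compound 3 (0.05 log units; that floor lies within the scatter) read as at least slightly lower numbers, but both floors lie within the scatter, so no real difference between the three is established.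

Compound 4, `COc1cc(-c2nnc3n2NC(c2ccco2)C(C(=O)c2ccco2)S3)cc(OC)c1OC`, is not yet measured. Its change from compound 3 is furan-2-yl in place of 4-nitrophenyl on a carbonyl carbon. Going by the values given here, no measured step involves a furan-2-yl on the carbonyl carbon, so the two floors above are the only guide, and they point to no step beyond the scatter in this assay in either direction. Compound 4 is therefore expected to land near compound 3, with a fair chance of another limit; its estimate is 100000 nM, between 40000 nM and 250000 nM. The expected step is a 1.1-fold higher number from compound 3 to compound 4 (0.06 log units; within the scatter).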

Compound 4, half-maximal inhibitory concentration: > 100000 nM
Compound 4 ended at the assay's limit; the forecaster's own chance of this, stated with the estimate: 60%; the middle value lies on the limit itself.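

For the compounds shown here, compound 4 puts a five-membered aromatic ring with 1 hetero atom on this carbonyl carbon, where the earlier compounds all carry a substituted phenyl ring, and in this assay compound 4 gives > 100000 nM, which is a limit of the assay and not a number. Exchanging 4-nitrophenyl for furan-2-yl gives an at least 1.1-fold higher number from compound 3 to compound 4 (0.05 log units; that floor lies within the scatter), so no real change is established, and the steps to the two other compounds cannot be read, as both ends of each step are limits. At this position, then, changing the type of aromatic ring has not produced a clear move to lower numbers, and the limit now holds most of the series: the limit of > 100000 nM in this assay, at which 3 of the 4 values shown sit.

Still open, from the compounds shown here alone, is whether an amine, a carboxylic acid or a longer alkyl chain on this carbonyl carbon would give a number clearly lower than those seen so far. The compounds shown also say nothing about changes elsewhere on the shared core, which is identical in all four.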